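Ethylsulfonamide in Place of a Methylpyrazole Group

This account rests on a few compounds, and the source may have more. Where it says the series, first, only, none or still open, it means among the compounds named here.

Measured compounds:
Compound 1, `c1ccc2c(c1)CCC2c1ncc[nH]1`: in a functional assay on CHO cells for agonist activity at Alpha-1D adrenergic receptor (Homo sapiens), read by FLIPR and calcium flux (on this read-out lower numbers stand for an effect already at smaller amounts and higher numbers for an effect only at larger amounts of compound), compound 1 gives > 10000 nM, a limit of the assay.
Compound 2, `CS(=O)(=O)Nc1cccc2c1CCC2c1ncc[nH]1`: in this assay compound 2 gives > 10000 nM, also a limit.
Compound 3, `Cn1cc(-c2cccc3c2CCC3c2ncc[nH]2)cn1`: in this assay compound 3 gives > 10000 nM, again a limit.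

Compound 3 stands at the limit of > 10000 nM in this assay, at which 3 of the 3 values shown sit. No number is known for it, only the statement that any effect would need more compound than the assay tested.

The unmeasured compound 4, `CCS(=O)(=O)Nc1cccc2c1CCC2c1ncc[nH]1`, differs from compound 3 in one place: (ethylsulfonyl)amino in place of 1-methyl-1H-pyrazol-4-yl on an aromatic carbon. The measured steps that bear on this change are a step that the two limits leave unreadable from compound 1 to compound 2, a step that the two limits leave unreadable from compound 1 to compound 3 and a step that the two limits leave unreadable from compound 2 to compound 3. Both ends of each step sit at the limit, so none of them has a readable size, and they give no hint of a direction. In particular, the step from an unsubstituted aromatic carbon to a methanesulfonamido group, and from there to the methylpyrazole, left every compound at the limit.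

With three limits and no readable step, the step that the limit leaves unreadable from compound 3 to compound 4 is expected to be none beyond the scatter. Compound 4 is expected to give 15000 nM in this assay. For compound 4 the expected range runs from 4000 nM to 60000 nM, most likely reported again as a limit.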

Compound 4, half-maximal effective concentration: > 10000 nM
Compound 4 was reported as a limit; the forecaster's own chance of this, stated with the estimate: 85%; the middle value lies beyond the limit too.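

Compound 4 gives only a limit in this assay, as do compound 1, compound 2 and compound 3, so none of the steps to compound 4 can be read: the limit of > 10000 nM in this assay, at which 4 of the 4 values shown sit. The compounds shown leave open whether any of them has an effect in this assay, and whether methanesulfonamido, (ethylsulfonyl)amino and 1-methyl-1H-pyrazol-4-yl differ there at all.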